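Amide versus sulfonamide on the ring nitrogen

The source may hold more compounds than are shown below. What is called first, only, known or untested is meant among the compounds shown, and "the series" means these compounds.

In a functional assay on B16-F10 cells (Mus musculus) for antiproliferative activity, read by MTT assay, with a stated time of 48 h (a lower number here means a stronger inhibitor, a higher number a weaker inhibitor), compound 3 `COc1ccc(-c2cn3cc(C4=CCN(S(=O)(=O)c5ccccc5)CC4)ccc3n2)cc1OC` gives 13200 nM. Compound 2 `COc1ccc(-c2cn3cc(C4=CCN(S(=O)(=O)C5CCCCC5)CC4)ccc3n2)cc1OC` gives 11100 nM, and compound 1 `COc1ccc(-c2cn3cc(C4=CCN(C(=O)C5CCCCC5)CC4)ccc3n2)cc1OC` gives 10900 nM; the three numbers do not separate, as a 1.0-fold higher number from compound 1 to compound 2 (0.01 log units; within the scatter), a 1.2-fold higher number from compound 1 to compound 3 (0.08 log units; within the scatter) and a 1.2-fold higher number from compound 2 to compound 3 (0.08 log units; within the scatter) show. Compound 4 `COc1ccc(-c2cn3cc(C4=CCN(C(=O)c5cccc(C(F)(F)F)c5)CC4)ccc3n2)cc1OC` carries (3-(trifluoromethyl)phenyl)carbonyl in place of phenylsulfonyl on an amine nitrogen in a ring. Among the compounds with values here, two measured steps bear on this: the exchange of sulfonyl for carbonyl, a 1.0-fold higher number from compound 1 to compound 2 (0.01 log units; within the scatter), and the exchange of cyclohexyl for phenyl on sulfur, a 1.2-fold higher number from compound 2 to compound 3 (0.08 log units; within the scatter), both within the scatter. Within the data shown here, the trifluoromethyl on the ring has no measured counterpart. The step to compound 4 in this assay is therefore expected to be a 1.1-fold lower number from compound 3 to compound 4 (0.04 log units; within the scatter), none beyond the scatter. Compound 4 is estimated at 12000 nM, between 5500 nM and 26000 nM.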

Compound 4, half-maximal inhibitory concentration: 7890 nM
Compound 4: middle estimate off by 1.5-fold (0.18 log units), on the high side; the range from low to high includes it.
By their numbers in this assay, from the lowest: compounds 4, 1, 2 and 3 (each within the scatter of the next).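

In this assay the new (3-(trifluoromethyl)phenyl)carbonyl group gives a 1.7-fold lower number from compound 3 to compound 4 (0.22 log units; within the scatter) and a 1.4-fold lower number from compound 2 to compound 4 (0.15 log units; within the scatter) and a 1.4-fold lower number from compound 1 to compound 4 (0.14 log units; within the scatter), all three within the scatter. The ring nitrogen therefore tolerates this larger group, with trifluoromethyl on the phenyl, without separating from the amide and sulfonamides seen so far. No supporting data bear on why these steps are small.

Phenylcarbonyl on this nitrogen would show whether the trifluoromethyl matters apart from the carbonyl. On these data alone, whether an amine or a carboxylic acid on the phenyl ring moves the number beyond the scatter stays open.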